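The source may report more compounds than this note shows. Statements on the series, on what has been measured and on what is new or still open speak of the compounds shown alone.

Among the compounds with values here, compound 1, with the structure `COc1cc(/C=N/c2c(C#N)ncn2-c2ccc(F)cc2)cc(OC)c1OC`, is the weaker of the two compounds measured so far in a functional assay on A549 cells (Homo sapiens) for antiproliferative activity, read by MTT assay, with a stated time of 48 h; a lower number here means a stronger inhibitor, a higher number a weaker inhibitor: it gives 9880 nM, while compound 2, with the structure `COc1ccc(/C=N/c2c(C#N)ncn2-c2ccc(F)cc2)cc1OC`, gives 2960 nM in this assay. Within the data shown here, the one step between these two, a 3.3-fold lower number from compound 1 to compound 2 (0.52 log units; beyond the scatter), comes from a hydrogen in place of a methoxy on an aromatic carbon and nothing else.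

Compound 3, with the structure `COc1cc(/C=N/c2c(C#N)ncn2Cc2ccc(F)cc2)cc(OC)c1OC`, is not yet measured. It differs from compound 1 in a single place: 4-fluorobenzyl in place of 4-fluorophenyl on an aromatic nitrogen. The aromatic nitrogen that carries this group is left untouched otherwise, and the three methoxy groups of compound 1 stay in place.

Among the measured compounds shown here, no measured step touches the group on that nitrogen, so the only step at hand, the removal of a methoxy from compound 1 to compound 2, does not bear on this change. With nothing to lean on, the expectation is a number close to that of compound 1, with a wide range on either side. Compound 3 is therefore estimated at 9000 nM, between 2500 nM and 32000 nM, which is an expected step of a 1.1-fold lower number from compound 1 to compound 3 (0.04 log units; within the scatter).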

Compound 3, half-maximal inhibitory concentration: 9710 nM
Beside the measured number, compound 3's estimate is 1.1-fold (0.03 log units) below it; the range from low to high includes it.
By their numbers in this assay, from the lowest: compound 2; then compounds 3 and 1 (each within the scatter of the next).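

In this assay, within the data shown here, the first change at the aromatic nitrogen, 4-fluorobenzyl in place of 4-fluorophenyl, gives a 1.0-fold lower number from compound 1 to compound 3 (0.01 log units; within the scatter), so the two compounds cannot be told apart. For this pair, then, the group on that nitrogen can go from 7 heavy atoms to 8 with no readable difference in antiproliferative activity, whereas the methoxy change gave a step beyond the scatter, a 3.3-fold lower number from compound 1 to compound 2 (0.52 log units; beyond the scatter), and this holds only for the core of compound 1. Nothing measured here explains why the two numbers match.

On these data alone, it remains open whether 4-fluorobenzyl and 4-fluorophenyl would also match on the core of compound 2, which gives 2960 nM and has a hydrogen where compound 1 has a methoxy. Also open, as far as these compounds go, is how far this tolerance extends at the nitrogen, for instance to a longer chain between the nitrogen and the fluorinated ring, or to a chain ending in an amine or a carboxylic acid.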